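Carboxybenzyl series: a positional isomer of compound 3

The compounds below may be only part of what the source reports. "The series", "measured", "known", "first", "only" and "open" are said of these compounds alone.

In an ADME assay on Sf9 cells for inhibition of Dipeptidyl peptidase 9 (Homo sapiens), read by fluorescence, with stated times of 60 s and 20 min (on this read-out higher numbers stand for weaker inhibition and lower numbers for stronger inhibition), compound 3 `CC#CCn1c(N2CCC[C@@H](N)C2)cc(=O)n(Cc2ccc(Br)cc2C(=O)O)c1=O` gives > 100000 nM, which is a limit and not a number. Compound 1 `CC#CCn1c(N2CCC[C@@H](N)C2)cc(=O)n(Cc2ccc(F)cc2C(=O)O)c1=O` likewise gives a limit, > 100000 nM. Compound 2 `CC#CCn1c(N2CCC[C@@H](N)C2)cc(=O)n(Cc2cccc(F)c2C(=O)O)c1=O` also gives a limit, > 100000 nM. All three measured values thus sit at the limit of > 100000 nM in this assay, at which 3 of the 3 values shown sit, and the steps between them cannot be read: a step that the two limits leave unreadable from compound 1 to compound 2; a step that the two limits leave unreadable from compound 1 to compound 3; a step that the two limits leave unreadable from compound 2 to compound 3. Compound 3 therefore stands with the other two at the limit, with nothing to rank it.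

Compound 4 `CC#CCn1c(N2CCC[C@@H](N)C2)cc(=O)n(Cc2cc(Br)ccc2C(=O)O)c1=O` differs from compound 3 by 5-bromo-2-carboxyphenyl in place of 4-bromo-2-carboxyphenyl on a saturated chain carbon bound to an aromatic nitrogen. Among the measured compounds shown here, the steps that bear on this change are the three above, each unreadable, so no size of step in this assay can be inferred from them; compounds 1, 2 and 3 show only that every halogen placement tried so far left the value at the limit. The step expected in this assay is a step that the limit leaves unreadable from compound 3 to compound 4, meaning compound 4 is expected to stay at or near the limit. The estimate for compound 4 is 200000 nM, with a range from 50000 nM to 1000000 nM.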

Compound 4, half-maximal inhibitory concentration: > 100000 nM
Compound 4 ended at the assay's limit; the forecaster's own chance of this, stated with the estimate: 85%; the middle value lies beyond the limit too.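

In this assay, compound 4 stands at a limit along with compound 1, compound 2 and compound 3, so no step among them can be read: the limit of > 100000 nM in this assay, at which 4 of the 4 values shown sit. The compounds shown leave open how far each lies beyond that limit, and whether any bromo or fluoro placement differs from another.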